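The source may hold more compounds than are shown below. What is called first, only, known or untested is meant among the compounds shown, and "the series" means these compounds.

Working notes on the series. Compound 1 `Clc1ccc(C[C@H]2COC[C@@H]2Cc2ccccc2)cc1Cl` gives 19000 nM in a functional assay on HL-60 cells (Homo sapiens) for cytotoxicity, read by WST assay, with a stated time of 48 h; on this read-out lower numbers stand for an effect already at smaller amounts and higher numbers for an effect only at larger amounts of compound. Compound 2 `COc1cccc(C[C@H]2COC(=O)[C@@H]2Cc2ccc(Cl)c(Cl)c2)c1` gives 34000 nM in this assay, and compound 3 `COc1cc(C[C@H]2COC(=O)[C@@H]2Cc2ccc(Cl)c(Cl)c2)ccc1O` gives 36000 nM; the difference between the cores of compound 1 and compound 2 is not broken down here. From compound 2 to compound 3 the change is hydroxy in place of hydrogen on an aromatic carbon and the step is a 1.1-fold higher number from compound 2 to compound 3 (0.02 log units; within the scatter). Compound 4 `Oc1ccccc1C[C@H]1COC[C@@H]1Cc1ccc(Cl)c(Cl)c1` is not yet measured; it differs from compound 1 by hydroxy in place of hydrogen on an aromatic carbon, the same kind of change, here ortho to a large group rather than ortho to a methoxy group and para to a large group. The expected step is a 1.2-fold higher number from compound 1 to compound 4 (0.06 log units; within the scatter), resting on the earlier step of a 1.1-fold higher number from compound 2 to compound 3 (0.02 log units; within the scatter) lying within the scatter. Compound 4 is therefore expected to give about 22000 nM in this assay, estimated between 9000 nM and 55000 nM.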

Compound 4, half-maximal effective concentration: 34000 nM
Estimate against measurement, compound 4: 1.5-fold (0.19 log units) below; measured number inside the range.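

In this assay, hydroxy in place of hydrogen on an aromatic carbon gives a 1.8-fold higher number from compound 1 to compound 4 (0.25 log units; within the scatter). Set beside the earlier step, the change reads the same on both cores: the same change on two cores in this assay, a 1.1-fold higher number (0.02 log units; within the scatter) from compound 2 to compound 3 and a 1.8-fold higher number (0.25 log units; within the scatter) from compound 1 to compound 4, 1.7-fold (0.23 log units) apart, within the scatter of two such steps. Within the data shown here, this shows only that the change produced no step beyond the scatter on either core, so it supports carrying over a null result and shows no transferable gain or loss, with just one pair per core behind it.

Going by these compounds, it remains open whether an amine or a carboxylic acid on the same aromatic carbon would give a step beyond the scatter. On these data alone, whether the hydroxy step would stay within the scatter on a third core is also open.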